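The source may report more compounds than this note shows. Statements on the series, on what has been measured and on what is new or still open speak of the compounds shown alone.

Values so far in a physicochemical assay for lipophilicity, using the shake flask method, in phosphate buffer, measured as octanol-water partition, with a stated time of 30 min, at pH 7.4; a lower number here means a more polar compound, a higher number a more lipophilic compound

- Compound 1 `O=C1c2ccccc2CN1c1cnc(NCc2c(F)ccc3c2CCO3)n2cnnc12` gives 2.7
- Compound 2 `O=C(Nc1cnc(NCc2c(F)ccc3c2CCO3)n2cnnc12)c1cccnc1` gives 2
- Compound 3 `C[C@H]1CC(=O)N(c2cnc(NCc3c(F)ccc4c3CCO4)n3cnnc23)C1` gives 1.8

Compound 3 stands at 1.8 in the low part of this small set. Two steps place it there (a number 0.90 log units lower from compound 1 to compound 3 (beyond the scatter)) and (a number 0.20 log units lower from compound 2 to compound 3 (within the scatter)). Compound 4 `O=C1CCCN1c1cnc(NCc2c(F)ccc3c2CCO3)n2cnnc12` carries hydrogen in place of methyl on a saturated ring carbon and so has 2-oxopyrrolidin-1-yl where compound 3 has 4-methyl-2-oxopyrrolidin-1-yl.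

Within the data shown here, no measured step isolates this change. All three exchange whole groups, so they bear on it only loosely. The two steps beyond the scatter (a number 0.70 log units lower from compound 1 to compound 2 (beyond the scatter)) and (a number 0.90 log units lower from compound 1 to compound 3 (beyond the scatter)) both took away heavy atoms and both lowered the number, while the third step stayed within the scatter. The change at hand is far smaller than either of those exchanges, so only a slight fall is expected, and it may not clear the scatter. The expected step is (a number 0.30 log units lower from compound 3 to compound 4 (within the scatter)) in this assay and no larger one is anticipated. For compound 4 the estimate is 1.5 with 1.2 to 1.8 as the expected range.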

Compound 4, distribution coefficient: 1.3
Beside the measured number, compound 4's estimate is 0.20 log units above it; the range from low to high includes it.
By their numbers in this assay, from the lowest: compound 4; then compounds 3 and 2 (each within the scatter of the next); then compound 1.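

In this assay, among these compounds, this is the first step that isolates the saturated ring carbon two ring bonds from the ring nitrogen, and losing the methyl there, a single carbon, gives a shift beyond the scatter (a number 0.50 log units lower from compound 3 to compound 4 (beyond the scatter)), whereas the whole-group exchange from compound 2 to compound 3 stayed within it. With 2-oxopyrrolidin-1-yl on the shared core, compound 4 also separates from the other two compounds (a number 0.70 log units lower from compound 2 to compound 4 (beyond the scatter)) (a number 1.40 log units lower from compound 1 to compound 4 (beyond the scatter)), which makes it the lowest of the four, with each of its steps beyond the scatter. No measurement here accounts for the size of the methyl step, so the result stands as an observation without an explanation.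

The compounds shown leave open where a hydroxyl, an amine or an ethyl chain on this same saturated ring carbon would fall relative to hydrogen and methyl, and whether methyl in the opposite configuration would give the same number. Going by these compounds, they rest on this one pair, so it also remains open whether the methyl step would carry over to a ring of another size or to another group on the shared core.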